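A few compounds are considered here, and "the series" means these few. Any claim that something is new, unique, unknown or untested is made for them only; others in the source may bear on it.

Working notes on the series, measured in a functional assay on MCF7 cells (Homo sapiens) for cytotoxicity, read by MTT assay, with a stated time of 48 h; a lower number here means a stronger inhibitor, a higher number a weaker inhibitor:

- compound 1 `CCCCCCC[C@@H](C/C=C/CCC(=O)N(C)C/C(=C\Cl)CC(=O)CC(=O)NC[C@H](O)CC(=O)OC)OC`: 29000 nM
- compound 2 `C=CCCC[C@@H]1OC(=O)CNC(=O)[C@H](Cc2ccccc2)N(C)C(=O)[C@@H]2CCCN2C(=O)[C@H](Cc2ccccc2)N(C)C(=O)[C@H](C(C)C)NC(=O)C1(C)C`: 30000 nM

Only these two values are available so far. Compound 2, at 30000 nM, stands level with compound 1 at 29000 nM, and the two lie within the scatter of each other. Neither can be ranked above the other on these numbers.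

The next compound to be tested is compound 3 `C#CCCC[C@@H]1OC(=O)CNC(=O)[C@H](Cc2ccccc2)N(C)C(=O)[C@@H]2CCCN2C(=O)[C@H](Cc2ccccc2)N(C)C(=O)[C@H](C(C)C)NC(=O)C1(C)C`, which keeps the core of compound 2 and changes one group: ethynyl in place of vinyl on a saturated chain carbon, three bonds along the chain from a saturated ring carbon. In words, ethynyl stands in place of vinyl on a saturated chain carbon, three bonds along the chain from a saturated ring carbon.

For the measured compounds named here, no two measured compounds differ in one place only, so the series offers no measured step to serve as a guide. The only reference for the expectation is compound 2 at 30000 nM. In this assay, no step beyond the scatter is expected, and no direction is favoured. The estimated step is no change at the digits printed from compound 2 to compound 3 (within the scatter). For compound 3 the expected value is 30000 nM, with an estimated range of 13000 nM to 70000 nM.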

Compound 3, half-maximal inhibitory concentration: 39000 nM
For compound 3 the middle estimate is 1.3-fold (0.11 log units) below the measured one; low and high end bracket the measured number.
By their numbers in this assay, from the lowest: compounds 1, 2 and 3 (each within the scatter of the next).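

In this assay, for the compounds shown here, the change of vinyl to ethynyl on a saturated chain carbon, three bonds along the chain from a saturated ring carbon, gives the first step that can be read: a 1.3-fold higher number from compound 2 to compound 3 (0.11 log units; within the scatter) (within the scatter). Read one bond further out, the same difference is pent-4-en-1-yl to pent-4-yn-1-yl, and on these numbers the double bond and the triple bond at this place cannot be told apart, with the rest of the core held constant. No measurement is at hand that bears on the reason for this result.

Both groups compared here have two carbons, so the step says nothing about a group of another kind at this place, and an amine, a carboxylic acid or a longer chain there could show whether this position can move the value in this assay beyond the scatter at all. From the compounds shown here alone, compound 1 differs from the other two in more than one place, so whether any feature of its structure matters in this assay also stays open.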